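A Third Methoxy on the Ketone-Bearing Ring

The compounds below may be only part of what the source reports. "The series", "measured", "known", "first", "only" and "open" are said of these compounds alone.

Of the compounds shown here, three built on the same core have been tested in a functional assay on A498 cells (Homo sapiens) for cytotoxicity, read by sulforhodamine B assay, with a stated time of 48 h, tested at 10 uM; a higher number here means a weaker effect of the compound at the concentration tested, a lower number a stronger effect. Compound 1, `COc1ccc(-c2cc(/C=C/C(=O)c3cc(OC)c(OC)c(OC)c3)[nH]n2)cc1OC`, gives -28%. Compound 2, `COc1ccc(C(=O)/C=C/c2cc(-c3cc(OC)c(OC)c(OC)c3)n[nH]2)cc1`, gives -57%. Compound 3, `COc1ccc(C(=O)/C=C/c2cc(-c3cc(OC)c(OC)c(OC)c3)n[nH]2)cc1OC`, gives -87%, the lowest of the three numbers and therefore the strongest effect among them; the nearest is compound 2 and the furthest is compound 1, both separated from it by more than the usual scatter.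

Compound 4, `COc1cc(C(=O)/C=C/c2cc(-c3cc(OC)c(OC)c(OC)c3)n[nH]2)cc(OC)c1OC`, has not yet been measured. It differs from compound 3 by methoxy in place of hydrogen on an aromatic carbon.

For the measured compounds named here, one measured step bears on this change: a number 30 percentage points lower from compound 2 to compound 3 (beyond the scatter), which is the same kind of change, methoxy in place of hydrogen on an aromatic carbon of the same ring. A further addition of the same group might therefore be expected to lower the number again. Compound 3 already sits close to the bottom of the scale this read-out allows, so any further drop must be small. For compound 4 the expected step is a number 5 percentage points lower from compound 3 to compound 4 (within the scatter). The estimate for compound 4 in this assay is -92%, with a range from -100% to -75%.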

Compound 4, a percentage reported as activity, at one concentration (the size of the read-out at that concentration, not a potency): -64%
The estimate for compound 4 lay 28 percentage points below the measured number, and the stated range ends below it.
By their numbers in this assay, from the lowest: compound 3; then compounds 4 and 2 (each within the scatter of the next); then compound 1.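

The third methoxy on the ketone-bearing ring reverses the trend: in this assay the step is a number 23 percentage points higher from compound 3 to compound 4 (beyond the scatter), whereas the previous addition to that ring gave a number 30 percentage points lower from compound 2 to compound 3 (beyond the scatter). The effect of this change therefore depends on where the methoxy goes and on what the ring already carries, and here the new group stands ortho to a methoxy group and meta to both a large group and another methoxy group. On a different core, the same exchange, a number 36 percentage points lower from compound 1 to compound 4 (beyond the scatter), runs in the direction of the earlier step, leaving the step from compound 3 to compound 4 as the one that goes against it: the same change on two cores in this assay, a number 30 percentage points lower (beyond the scatter) from compound 2 to compound 3 and a number 36 percentage points lower (beyond the scatter) from compound 1 to compound 4, 6 percentage points apart, within the scatter of two such steps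

The compounds shown leave open whether the higher number belongs to methoxy itself or would follow any group at this carbon, a question that a hydroxyl, an amine or a chlorine atom at the same place could begin to answer. The read-out also comes from a single concentration, so it leaves open how the potencies of these compounds compare.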